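Three inactive analogues and a fourth awaiting its number

The compounds below may be only part of what the source reports. "The series", "measured", "known", "first", "only" and "open" are said of these compounds alone.

Measured so far:
compound 1 `COc1ccc2c(/C=C(\C#N)C(=O)c3c[nH]c4cc(F)ccc34)c[nH]c2c1` — > 50000 nM
compound 2 `COc1ccc2c(/C=C(\C#N)C(=O)c3c[nH]c4cc(OC)ccc34)c[nH]c2c1` — > 50000 nM
compound 3 `COc1ccc2[nH]cc(/C=C(\C#N)C(=O)c3c[nH]c4cc(F)ccc34)c2c1` — > 50000 nM

All three measured compounds were tested in a functional assay on MIA PaCa-2 cells (Homo sapiens) for cytotoxicity, read by WST assay, with a stated time of 24 h; on this read-out lower numbers stand for stronger inhibition and higher numbers for weaker inhibition. For compound 1 the result is a limit of the assay rather than a number, > 50000 nM. For compound 2 the result is likewise only a limit, > 50000 nM. For compound 3 the value is again a limit, > 50000 nM. The change from compound 1 to compound 2 is methoxy in place of fluoro on an aromatic carbon, and the step that the two limits leave unreadable from compound 1 to compound 2 cannot be read, because of the limit of > 50000 nM in this assay, at which 3 of the 3 values shown sit.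

Compound 3 shares its atoms with compound 1 but joins them differently; the difference between the two cores is not broken down here. Compound 4 `COc1ccc2c(C(=O)/C(C#N)=C/c3c[nH]c4ccc(OC)cc34)c[nH]c2c1` is not yet measured in this assay. It differs from compound 3 by methoxy in place of fluoro on an aromatic carbon, the same change that separates compound 1 from compound 2, made on the core of compound 3.

For compound 4 the step that the limit leaves unreadable from compound 3 to compound 4 is expected to be unreadable in the same way, resting on compound 1 at > 50000 nM and compound 2 at > 50000 nM, both limits. Compound 4 is therefore estimated at 70000 nM, most likely reported once more as a limit, within a range of 20000 nM to 300000 nM.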

Compound 4, half-maximal inhibitory concentration: > 50000 nM
Compound 4 gave a limit, no number; the forecaster's own chance of this, stated with the estimate: 85%; the middle value lies beyond the limit too.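

The change to methoxy in place of fluoro gives no readable step between compound 3 and compound 4, because both results are limits and not numbers: the limit of > 50000 nM in this assay, at which 4 of the 4 values shown sit.

The compounds shown leave open how strongly any of the four acts in this assay and whether methoxy in place of fluoro makes any difference to that result on either core.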